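Replacing the 4-(thiophen-3-yl)phenyl group of compound 3

The source may report more compounds than this note shows. Statements on the series, on what has been measured and on what is new or still open speak of the compounds shown alone.

In a functional assay on HCT-116 cells (Homo sapiens) for inhibition, with a stated time of 72 h (a lower number here means a stronger inhibitor, a higher number a weaker inhibitor), compound 3 (`NC1CCC(Nc2nc(NCc3ccc(-c4ccsc4)cc3)c3ncn(C4CCCC4)c3n2)CC1`) gives 315 nM. Compound 2 (`COc1ccccc1-c1ccc(CNc2nc(NC3CCC(N)CC3)nc3c2ncn3C2CCCC2)cc1`) gives 430 nM, which is within the scatter of compound 3, and compound 1 (`NC1CCC(Nc2nc(NCc3ccc(Br)cc3)c3ncn(C4CCCC4)c3n2)CC1`) gives 790 nM. For the measured compounds named here, the modest 2.5-fold lower number from compound 1 to compound 3 (0.40 log units; beyond the scatter) is the only measured step beyond the scatter, while a 1.8-fold lower number from compound 1 to compound 2 (0.26 log units; within the scatter) and a 1.4-fold lower number from compound 2 to compound 3 (0.14 log units; within the scatter) both stay within it.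

Compound 4 (`NC1CCC(Nc2nc(NCc3ccc(-c4ccco4)nc3)c3ncn(C4CCCC4)c3n2)CC1`) carries 6-(furan-2-yl)pyridin-3-yl in place of 4-(thiophen-3-yl)phenyl on a saturated chain carbon bound to a nitrogen on an aromatic ring.

The three measured steps bear only on the outer group, and all keep the six-membered aromatic ring of carbon only. Going by the values given here, the exchange of that ring has no measured precedent here, so the range stays wide. With a 1.4-fold lower number from compound 2 to compound 3 (0.14 log units; within the scatter) as the closest guide, no step beyond the scatter is expected in either direction. The estimated step is a 1.1-fold higher number from compound 3 to compound 4 (0.05 log units; within the scatter). The estimate for compound 4 is 350 nM, with an expected range of 120 nM to 1000 nM.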

Compound 4, half-maximal inhibitory concentration: 86 nM
Compound 4: the middle estimate sits 4.1-fold (0.61 log units) above what was measured, and the stated range ends above it.
By their numbers in this assay, from the lowest: compound 4; then compounds 3, 2 and 1 (each within the scatter of the next, the first and the last beyond it).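

In this assay, the position tolerates more than a change of the outer group: exchanging the whole substituent gives a 3.7-fold lower number from compound 3 to compound 4 (0.56 log units; beyond the scatter), and the comparison with the bromo compound gives a 9.2-fold lower number from compound 1 to compound 4 (0.96 log units; beyond the scatter). This exchange is the first shown to alter the six-membered aromatic ring, which now carries a hetero atom, but it also replaces thiophen-3-yl with furan-2-yl, so the step belongs to the two changes together and cannot be divided between them. No available evidence accounts for the lower number.

On these data alone, the separate contributions of the two rings remain open, and 6-(thiophen-3-yl)pyridin-3-yl and 4-(furan-2-yl)phenyl would each isolate one of them. Also open, as far as these compounds go, is whether a morpholine or a carboxylic acid in place of furan-2-yl would be accepted on the pyridine ring.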